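Adding methoxy to compound 3: working notes

This account rests on a few compounds, and the source may have more. Where it says the series, first, only, none or still open, it means among the compounds named here.

Measured so far in a functional assay on HL-60 cells (Homo sapiens) for cytotoxicity, read by WST assay, with a stated time of 48 h; a lower number here means that less compound is needed, a higher number that more compound is needed for the effect
compound 1 `O=C1OC[C@H](Cc2ccccc2)[C@H]1Cc1ccc(Cl)c(Cl)c1` gives 19000 nM
compound 2 `COc1cccc(C[C@H]2COC(=O)[C@@H]2Cc2ccc(Cl)c(Cl)c2)c1` gives 34000 nM
compound 3 `O=C1OC[C@H](Cc2ccc(O)cc2)[C@H]1Cc1ccc(Cl)c(Cl)c1` gives 37000 nM

Compound 3 lies within the scatter of both other compounds, with a 1.9-fold higher number from compound 1 to compound 3 (0.29 log units; within the scatter) and a 1.1-fold higher number from compound 2 to compound 3 (0.04 log units; within the scatter) as its steps. Compound 4 `COc1cc(C[C@H]2COC(=O)[C@@H]2Cc2ccc(Cl)c(Cl)c2)ccc1O` follows from compound 3 by methoxy in place of hydrogen on an aromatic carbon in the form of methoxy in place of hydrogen on an aromatic carbon, ortho to a hydroxy group. Among the measured compounds shown here, two measured steps bear on this change, a 1.8-fold higher number from compound 1 to compound 2 (0.25 log units; within the scatter) for methoxy and a 1.9-fold higher number from compound 1 to compound 3 (0.29 log units; within the scatter) for hydroxy, both within the scatter. For the measured compounds named here, no measured compound carries both groups. No step beyond the scatter is therefore expected in this assay and the estimated 1.0-fold lower number from compound 3 to compound 4 (0.01 log units; within the scatter) is expected to stay within it. For compound 4 the estimated value is 36000 nM with an expected range from 16000 nM to 80000 nM as the working estimate.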

Compound 4, half-maximal effective concentration: 36000 nM
Estimate against measurement, compound 4: no gap at the digits printed; low and high end bracket the measured number.
By their numbers in this assay, from the lowest: compounds 1, 2, 4 and 3 (each within the scatter of the next).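

Compound 4, the only compound shown with both groups, places methoxy ortho to a hydroxy group and gives a 1.0-fold lower number from compound 3 to compound 4 (0.01 log units; within the scatter) in this assay. The methoxy change thus stays within the scatter on a second core: the same change on two cores in this assay, a 1.8-fold higher number (0.25 log units; within the scatter) from compound 1 to compound 2 and a 1.0-fold lower number (0.01 log units; within the scatter) from compound 3 to compound 4, 1.8-fold (0.26 log units) apart, within the scatter of two such steps

Hydroxy on the core of compound 2 gives a 1.1-fold higher number from compound 2 to compound 4 (0.02 log units; within the scatter), and this change also agrees across two cores: the same change on two cores in this assay, a 1.9-fold higher number (0.29 log units; within the scatter) from compound 1 to compound 3 and a 1.1-fold higher number (0.02 log units; within the scatter) from compound 2 to compound 4, 1.8-fold (0.26 log units) apart, within the scatter of two such steps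

Only hydrogen, hydroxy and methoxy are shown on this ring. As far as these compounds go, whether an amine or a carboxylic acid at this position would give a step beyond the scatter remains open.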